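This account rests on a few compounds, and the source may have more. Where it says the series, first, only, none or still open, it means among the compounds named here.

Measured compounds:
compound 1, `CCC(C)C(NC(=O)NO)C(=O)NC(c1ccccc1)c1ccccc1`: >= 100000 nM
compound 2, `O=C1NC(c2ccccc2)C(=O)N1C1CCCC1`: > 100000 nM

In a functional assay on SW-620 cells (Homo sapiens) for inhibition (a higher number here means a weaker inhibitor, a lower number a stronger inhibitor), compound 1 reaches only a limit of the assay, >= 100000 nM, not a number. Compound 2 likewise gives only a limit in this assay, > 100000 nM. On the numbers shown, compound 2 therefore stands at the limit (the limit of > 100000 nM in this assay, at which 1 of the 2 values shown sits). For the measured compounds named here, the one other value shown is a limit as well, (the limit of >= 100000 nM in this assay, at which 1 of the 2 values shown sits). Compound 3, `CC(C)C1NC(=O)N(C2CCCC2)C1=O`, differs from compound 2 in one place: isopropyl in place of phenyl on a saturated ring carbon. Going by the values given here, no step between two measured compounds is available here, so there is nothing against which to scale this change. With both measured compounds sitting at limits, no step beyond the scatter in either direction is expected in this assay, and compound 3 is expected to remain at the limit. For compound 3 the estimate is 100000 nM, ranging from 30000 nM to 300000 nM. That estimate means an expected step of a number no higher from compound 2 to compound 3 (the limit leaves the size open).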

Compound 3, half-maximal inhibitory concentration: > 100000 nM
Compound 3 ended at the assay's limit; the forecaster's own chance of this, stated with the estimate: 85%; the middle value sits exactly at the limit.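

For the compounds shown here, compound 2 and compound 3 both stop at the limit of this assay, so no step between them can be read. Whether isopropyl in place of phenyl changes inhibition at all stays open, as does the true strength of each compound shown.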